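A larger group on the amide-type nitrogen of compound 2

The source may hold more compounds than are shown below. What is called first, only, known or untested is meant among the compounds shown, and "the series" means these compounds.

compound 1 `COc1cc(NC(C)CCCNC(=O)NNC(=O)Nc2ccc(C(F)(F)F)cc2)c2ncccc2c1`: 15000 nM
compound 2 `COc1cc(NC(C)CCCNC(=O)Nc2ccc(F)cc2)c2ncccc2c1`: 20000 nM
compound 3 `COc1cc(NC(C)CCCNC(=O)Nc2ccc(Cl)cc2)c2ncccc2c1`: 18000 nM

In a functional assay on HeLa cells (Homo sapiens) for inhibition, read by MTT assay, with a stated time of 72 h (on this read-out higher numbers stand for weaker inhibition and lower numbers for stronger inhibition), compound 2, at 20000 nM, stands within the scatter of both compound 1 and compound 3. The unmeasured compound 4 `COc1cc(NC(C)CCCNC(=O)NNC(=O)Nc2cccc(Cl)c2)c2ncccc2c1` departs from compound 2 as follows: ((3-chlorophenyl)carbamoyl)amino in place of 4-fluorophenyl on an amide-type nitrogen. In words, ((3-chlorophenyl)carbamoyl)amino takes the place of 4-fluorophenyl on an amide-type nitrogen. Among the compounds with values here, the one measured step, a 1.1-fold lower number from compound 2 to compound 3 (0.05 log units; within the scatter), puts chloro in place of fluoro on an aromatic carbon and stays within the scatter. Compound 1, which carries a similar carbamoyl-amino extension but with trifluoromethyl instead of chloro, gives 15000 nM. The expected step in this assay is therefore a 1.3-fold lower number from compound 2 to compound 4 (0.10 log units; within the scatter), none beyond the scatter. Compound 4 is estimated at 16000 nM, with an expected range from 8000 nM to 32000 nM.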

Compound 4, half-maximal inhibitory concentration: 44000 nM
For compound 4 the middle estimate is 2.8-fold (0.44 log units) below the measured one; the whole stated range lies below it.
By their numbers in this assay, from the lowest: compounds 1, 3 and 2 (each within the scatter of the next); then compound 4.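

In this assay, within the data shown here, ((3-chlorophenyl)carbamoyl)amino on this amide-type nitrogen gives the first steps beyond the scatter: a 2.2-fold higher number from compound 2 to compound 4 (0.34 log units; beyond the scatter), and a 2.4-fold higher number from compound 3 to compound 4 (0.39 log units; beyond the scatter). The extension alone does not set this outcome: compound 1 carries it too, yet stands within the scatter of compound 2. With the extension kept, 3-chlorophenyl in place of 4-(trifluoromethyl)phenyl gives a 2.9-fold higher number from compound 1 to compound 4 (0.47 log units; beyond the scatter).

No evidence at hand accounts for these steps. Still open, from the compounds shown here alone, is how the extension would read with 4-chlorophenyl, or with an amine on its ring.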